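The source may hold more compounds than are shown below. What is called first, only, known or untested is meant among the compounds shown, and "the series" means these compounds.

Of the compounds shown here, three of one family have been measured in a functional assay on T-24 cells (Homo sapiens) for antiproliferative activity, read by crystal violet staining, with a stated time of 96 h; on this read-out higher numbers stand for an effect only at larger amounts of compound and lower numbers for an effect already at smaller amounts. Compound 1 `O[C@@H]1[C@@H](O)[C@H](Oc2cc3ccccc3cc2S)OC[C@H]1O` gives 145 uM in this assay. Compound 2 `O[C@@H]1[C@@H](O)[C@H](Oc2ccc3ccc(S)cc3c2)OC[C@H]1O`, which carries a free sulfanyl group on its core, gives 360 uM in this assay. Compound 3 `Oc1ccc(S[C@@H]2OC[C@@H](O)[C@H](O)[C@H]2O)c2ccccc12` gives 160 uM in this assay. Of the three, compound 2 stands highest: the values of compound 3 and of compound 1 both lie beyond the usual scatter below it, so compound 2 needs a larger amount than either of them to reach the half-maximal effect.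

Compound 4 `CCCSc1ccc2ccc(O[C@@H]3OC[C@@H](O)[C@H](O)[C@H]3O)cc2c1` has not yet been measured. It differs from compound 2 in a single place: propyl in place of hydrogen on a sulfur, so that the free sulfanyl group of compound 2 becomes a propylsulfanyl group. Among the measured compounds shown here, no measured pair in this small set shows what such a change does, so neither the size nor the direction of the step can be read from what is known; the expectation rests on compound 2 alone. Compound 4 is expected to come out close to compound 2, with an expected 1.3-fold lower number from compound 2 to compound 4 (0.11 log units; within the scatter) in this assay that stays within the scatter. For compound 4 the estimate in this assay is 280 uM, with a range from 90 uM to 800 uM.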

Compound 4, concentration for half-maximal effect: 60 uM
Compound 4: middle estimate off by 4.7-fold (0.67 log units), on the high side; the whole stated range lies above it.
By their numbers in this assay, from the lowest: compound 4; then compounds 1 and 3 (each within the scatter of the next); then compound 2.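

In this assay the sulfur on the shared core proves to be a place where a change counts: propyl in place of hydrogen on that sulfur gives a 6.0-fold lower number from compound 2 to compound 4 (0.78 log units; beyond the scatter), and so, in this pair, the free sulfanyl group can be replaced without losing the effect. Among the compounds shown here, the earlier compounds could not show this, since no two of them differed in only one place, so this is the first step in the set with both a known direction and a known size. Nothing given here explains why the propylsulfanyl group goes with the lower number.

A single step cannot tell whether the number follows the length of the chain or something else about it: a methyl, a longer chain such as hexyl, or a propyl chain ending in an amine or a carboxylic acid, each on the same sulfur, would begin to answer that. As far as these compounds go, it also remains open whether propyl on the sulfur of compound 1 would move the number in the same direction and by a similar amount.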